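Swapping Chlorine for Bromine on Two Related Cores

This account rests on a few compounds, and the source may have more. Where it says the series, first, only, none or still open, it means among the compounds named here.

Compound 1 `Cn1c(=O)[nH]c2nc(SCC(=O)c3ccc(Cl)cc3)[nH]c2c1=O` and compound 2 `Cn1c(=O)[nH]c2nc(SCC(=O)c3ccc(Br)cc3)[nH]c2c1=O` share one core, while compound 3 `Cn1c(=O)c2[nH]c(SC/C(=N/O)c3ccc(Cl)cc3)nc2n(C)c1=O` and compound 4 `Cn1c(=O)c2[nH]c(SC/C(=N/O)c3ccc(Br)cc3)nc2n(C)c1=O` share another; the difference between the two cores is not broken down here. In a functional assay on MCF7 cells (Homo sapiens) for inhibition, read by MTT assay, with a stated time of 48 h (on this read-out lower numbers stand for stronger inhibition and higher numbers for weaker inhibition), compound 1 gives 6300 nM and compound 2 gives 11200 nM. The change between them, (bromo in place of chloro on an aromatic carbon), made a step of a 1.8-fold higher number from compound 1 to compound 2 (0.25 log units; within the scatter). In this assay compound 3 gives 1000 nM, the lowest of the three measured numbers. Compound 4 carries the same change on the other core, (bromo in place of chloro on an aromatic carbon). Because the earlier step of a 1.8-fold higher number from compound 1 to compound 2 (0.25 log units; within the scatter) stayed within the scatter, a similarly small step is expected here, a 1.5-fold higher number from compound 3 to compound 4 (0.18 log units; within the scatter). Compound 4 is therefore estimated to give 1500 nM, with a likely range from 700 nM to 3500 nM.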

Compound 4, half-maximal inhibitory concentration: 1300 nM
Beside the measured number, compound 4's estimate is 1.2-fold (0.06 log units) above it, within the range that was stated.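

In this assay, bromo in place of chloro on the second core gave a small step, a 1.3-fold higher number from compound 3 to compound 4 (0.11 log units; within the scatter). Set beside the earlier step, the change behaves alike on the two cores: the same change on two cores in this assay, a 1.8-fold higher number (0.25 log units; within the scatter) from compound 1 to compound 2 and a 1.3-fold higher number (0.11 log units; within the scatter) from compound 3 to compound 4, 1.4-fold (0.14 log units) apart, within the scatter of two such steps. This shows only that the move from 4-chlorophenyl to 4-bromophenyl stayed within the scatter in these two pairs; it does not show that the same would hold on a third core, or for any other change at this place.

The compounds shown all carry chloro or bromo at this place, so the effect of an amine, a methoxy group or a carboxylic acid there remains open. Also open, as far as these compounds go, is how each separate difference between the two cores affects the number.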